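Replacing 3-hydroxypropyl with 4-hydroxycyclohexyl on the shared core

A few compounds are considered here, and "the series" means these few. Any claim that something is new, unique, unknown or untested is made for them only; others in the source may bear on it.

- Compound 1 `COc1ccc(-c2c(-c3ccc(OC)cc3)n(Cc3ccccc3)c3ncn(CCCO)c(=N)c23)cc1`: > 20000 nM
- Compound 2 `N=c1c2c(-c3ccccc3)c(-c3ccccc3)n(CC3CCCCC3)c2ncn1C1CCOCC1`: 2020 nM; 2000 nM (2 entries)

The two compounds were tested in a functional assay on PC-3M cells (Homo sapiens) for antiproliferative activity, read by microscopy, with a stated time of 24 h; a lower number here means a stronger inhibitor, a higher number a weaker inhibitor. Compound 1 stands at a limit of the assay, > 20000 nM, and has no single number. Compound 3 `COc1ccc(-c2c(-c3ccc(OC)cc3)n(Cc3ccccc3)c3ncn([C@H]4CC[C@H](O)CC4)c(=N)c23)cc1` keeps the core of compound 1 and places 4-hydroxycyclohexyl in place of 3-hydroxypropyl on an aromatic nitrogen. Within the data shown here, no measured pair isolates this change, so the expected size of the step in this assay is uncertain. A moderate move towards stronger inhibition is expected, partly because compound 2 at 2020 nM; 2000 nM (2 entries) also has a ring on that nitrogen, though it differs elsewhere too. The expected change is an at least 3.3-fold lower number from compound 1 to compound 3 (0.52 log units; beyond the scatter). Compound 3 is estimated at 6000 nM, with an expected range of 1500 nM to 20000 nM.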

Compound 3, half-maximal inhibitory concentration: > 20000 nM
Compound 3 was reported as a limit; the forecaster's own chance of this, stated with the estimate: 35%; middle value at least 3.3-fold (0.52 log units) from the limit.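

In this assay compound 3 gives > 20000 nM, which is a limit of the assay and not a number. Among these compounds, compound 1 also stands at a limit, so no step from compound 1 to compound 3 can be read. The compounds shown leave open whether 4-hydroxycyclohexyl in place of 3-hydroxypropyl on an aromatic nitrogen changes inhibition at all.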